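The source may report more compounds than this note shows. Statements on the series, on what has been measured and on what is new or still open speak of the compounds shown alone.

Measured so far in a functional assay on CHO cells for inhibition of metabotropic glutamate receptor 5 (Rattus norvegicus), read by FLIPR and calcium flux; a lower number here means a stronger inhibitor, a higher number a weaker inhibitor:
- compound 1 `Cc1ccc2ccc(-c3cccc(Cl)c3)cc2n1` gives 14000 nM
- compound 2 `COc1ccccc1-c1ccc2ccc(C)nc2c1` gives 4200 nM
- compound 3 `Cc1ccc2ccc(-c3cc(F)cc(C#N)c3)cc2n1` gives 0.8 nM

Compound 3 stands lowest of the three numbers in this assay. Its nearest neighbour is compound 2, whose number is higher by an amount well beyond the scatter; compound 1 lies further still. Among the measured compounds shown here, all three share the same core and differ only in the pendant aromatic ring; no pair among them differs in a single place, so no single step can be separated out.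

Compound 4 `COCc1cc(C#N)cc(-c2ccc3ccc(C)nc3c2)c1` has not yet been measured in this assay. It differs from compound 3 in one place: methoxymethyl in place of fluoro on an aromatic carbon. The cyano group stays; only the fluoro is exchanged for the methoxymethyl. For the measured compounds named here, no measured pair speaks to this exchange directly. A small shift toward a higher number is expected, a 3.8-fold higher number from compound 3 to compound 4 (0.57 log units; beyond the scatter), with the step in this assay not far beyond the scatter. For compound 4 the estimate in this assay is 3 nM, in the range 0.5 nM to 20 nM.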

Compound 4, half-maximal inhibitory concentration: 2 nM
Estimate against measurement, compound 4: 1.5-fold (0.18 log units) above, within the range that was stated.
By their numbers in this assay, from the lowest: compound 3; then compound 4; then compound 2; then compound 1.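

In this assay, the place meta to a cyano group accepts methoxymethyl with 3 heavy atoms and 1 hydrogen-bond acceptor in place of the single fluorine of fluoro, at a modest cost: a 2.5-fold higher number from compound 3 to compound 4 (0.40 log units; beyond the scatter). Among the compounds shown here, with the cyano group kept, fluoro is therefore not required at this place for compound 4 to reach 2 nM, which the earlier compounds could not show, as no two of them differ in one place. No supporting measurement bears on the reason for this step, so it cannot be assigned to the loss of fluoro or the gain of methoxymethyl.

From the compounds shown here alone, whether the oxygen of methoxymethyl matters remains open; an ethyl group, a longer carbon chain or an aminomethyl group at this place would test that. For the compounds shown here, also open is whether the same exchange behaves alike without the cyano group, as this single pair is the only reading for the position.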